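A few compounds are considered here, and "the series" means these few. Any claim that something is new, unique, unknown or untested is made for them only; others in the source may bear on it.

In a functional assay on MCF7 cells (Homo sapiens) for cytotoxicity, read by MTT assay, with a stated time of 96 h (a higher number here means a weaker inhibitor, a lower number a stronger inhibitor), compound 3 `COc1cc(C(=O)c2cn(-c3ccc(C)cc3)cc2-c2ccccc2[N+](=O)[O-])cc(OC)c1OC` gives 65 nM, within the scatter of compound 2 `COc1cc(C(=O)c2cn(-c3ccc(C)cc3)cc2-c2ccccc2F)cc(OC)c1OC` at 44 nM. Compound 1 `COc1cc(C(=O)c2cn(-c3cccc(C)c3)cc2-c2ccc([N+](=O)[O-])cc2)cc(OC)c1OC` gives 780 nM, clearly higher than both. Compound 4 `COc1cc(C(=O)c2cn(-c3ccc(C)cc3)cc2-c2ccc([N+](=O)[O-])cc2)cc(OC)c1OC` has 4-nitrophenyl in place of 2-nitrophenyl on an aromatic carbon. For the measured compounds named here, the only measured step, a 1.5-fold higher number from compound 2 to compound 3 (0.17 log units; within the scatter), is nitro in place of fluoro and lies within the scatter, so it says little about this change. Going by the values given here, the sole measured compound carrying 4-nitrophenyl is compound 1 at 780 nM, which is one compound only but suggests a higher number in this assay. A rise beyond the scatter is therefore expected, a 4.6-fold higher number from compound 3 to compound 4 (0.66 log units; beyond the scatter). For compound 4 the estimated value is 300 nM, with an expected range of 90 nM to 900 nM.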

Compound 4, half-maximal inhibitory concentration: 200 nM
Compound 4: middle estimate off by 1.5-fold (0.18 log units), on the high side; low and high end bracket the measured number.
By their numbers in this assay, from the lowest: compounds 2 and 3 (each within the scatter of the next); then compound 4; then compound 1.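

In this assay, 4-nitrophenyl in place of 2-nitrophenyl gives a 3.1-fold higher number from compound 3 to compound 4 (0.49 log units; beyond the scatter), and against 2-fluorophenyl it gives a 4.5-fold higher number from compound 2 to compound 4 (0.66 log units; beyond the scatter), so where the nitro group sits on this phenyl ring matters in this pair. With 4-nitrophenyl held, 4-methylphenyl in place of 3-methylphenyl on the aromatic nitrogen gives a 3.9-fold lower number from compound 1 to compound 4 (0.59 log units; beyond the scatter), so 4-nitrophenyl alone does not set the number. No supporting measurement bears on either shift.

Still open, as far as these compounds go, is whether an amine or a carboxylic acid in place of the nitro group would follow the same trend at this position.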